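This account rests on a few compounds, and the source may have more. Where it says the series, first, only, none or still open, it means among the compounds named here.

Measured so far in a functional assay on U-87MG ATCC cells (Homo sapiens) for inhibition, read by MTT assay, with a stated time of 72 h; on this read-out lower numbers stand for stronger inhibition and higher numbers for weaker inhibition:
compound 1 `COc1cc2c(Oc3ccc(NC(=O)c4nn(-c5ccccc5OC(F)(F)F)c(=O)cc4C)cc3F)ccnc2cc1OCCCN1CCCCC1`: 1300 nM
compound 2 `COc1cc2c(Oc3ccc(NC(=O)c4nn(-c5ccccc5OC(F)(F)F)c(=O)cc4C)cc3F)ccnc2cc1OCCCN1CCC(C)CC1`: 800 nM

Compound 2 has the lower of the two numbers, but a 1.6-fold lower number from compound 1 to compound 2 (0.21 log units; within the scatter) lies within the scatter, so the two are not distinguished. Compound 3 `COc1cc2c(Oc3ccc(NC(=O)c4nn(-c5ccc(Cl)cc5)c(=O)cc4C)cc3F)ccnc2cc1OCCCN1CCC(C)CC1` differs from compound 2 by 4-chlorophenyl in place of 2-(trifluoromethoxy)phenyl on an aromatic nitrogen. Among the compounds with values here, the only measured step concerns the saturated ring, not the aryl on the ring nitrogen, so nothing measured bears on this change; no step beyond the scatter is expected in either direction, with wide uncertainty. Compound 3 is therefore estimated at 800 nM, range 250 nM to 2500 nM, meaning no change at the digits printed from compound 2 to compound 3 (within the scatter) is expected.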

Compound 3, half-maximal inhibitory concentration: 1350 nM
Estimate against measurement, compound 3: 1.7-fold (0.23 log units) below; low and high end bracket the measured number.
By their numbers in this assay, from the lowest: compounds 2, 1 and 3 (each within the scatter of the next).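

In this assay, within the data shown here, the first reading on the aryl at this ring nitrogen is a 1.7-fold higher number from compound 2 to compound 3 (0.23 log units; within the scatter). The earlier compounds shown here varied only the saturated ring; here, 4-chlorophenyl and 2-(trifluoromethoxy)phenyl are not distinguished, so this exchange on the aromatic nitrogen gives no measurable separation. No supporting data bear on this result.

Still open, going by these compounds, is whether an unsubstituted phenyl or a pyridyl on this nitrogen would separate from these two groups. Also open, on these data alone, is whether 4-chlorophenyl reads alike on the saturated ring without the methyl.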